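Swapping the aryl group on the shared core

The source may report more compounds than this note shows. Statements on the series, on what has been measured and on what is new or still open speak of the compounds shown alone.

Compound 1, `CC(C)(C)CC[C@H](c1ccc(C(=O)NCc2nn[nH]n2)cc1)N1C(=O)C(c2cncc(Cl)c2)=N[C@]12CC[C@@H](C(C)(C)C)CC2`: 38 nM
Compound 2, `CC(C)(C)CC[C@H](c1ccc(C(=O)NCc2nn[nH]n2)cc1)N1C(=O)C(c2cccc(C(F)(F)F)c2)=N[C@]12CC[C@@H](C(C)(C)C)CC2`: 13 nM

In an assay on CHO cells for displacement of a labelled ligand from Glucagon receptor (Homo sapiens), read by scintillation counting, with a stated time of 60 min (on this read-out lower numbers stand for stronger inhibition and higher numbers for weaker inhibition), compound 2 gives the lower of the two numbers, and its nearest neighbour is compound 1; the step of a 2.9-fold lower number from compound 1 to compound 2 (0.47 log units; beyond the scatter) lies beyond the scatter. Compound 3, `CC(C)(C)CC[C@H](c1ccc(C(=O)NCc2nn[nH]n2)cc1)N1C(=O)C(c2ccc(F)cc2)=N[C@]12CC[C@@H](C(C)(C)C)CC2`, is not yet measured; it differs from compound 2 by 4-fluorophenyl in place of 3-(trifluoromethyl)phenyl on a carbon with a double bond to nitrogen. Going by the values given here, only one measured step touches this place on the core, and it swapped a different group, so it is a rough guide. A step toward a higher number is expected, a 3.1-fold higher number from compound 2 to compound 3 (0.49 log units; beyond the scatter). Compound 3 is estimated at 40 nM, with a range from 12 nM to 130 nM.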

Compound 3, half-maximal inhibitory concentration: 13 nM
Beside the measured number, compound 3's estimate is 3.1-fold (0.49 log units) above it, and the stated range covers the measured number.
By their numbers in this assay, from the lowest: compounds 2 and 3 (each within the scatter of the next); then compound 1.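

In this assay, exchanging one carbon-only aromatic ring for another leaves the number unchanged, no change at the digits printed from compound 2 to compound 3 (within the scatter), although 4-fluorophenyl has fewer heavy atoms than 3-(trifluoromethyl)phenyl and carries its fluorine differently. Replacing 5-chloropyridin-3-yl with 4-fluorophenyl gives a 2.9-fold lower number from compound 1 to compound 3 (0.47 log units; beyond the scatter), so this second phenyl group also lands beyond the scatter from the ring containing nitrogen. No supporting measurement explains either result. Going by these compounds, it remains open whether unsubstituted phenyl would behave like these two groups, and whether an amine or a carboxylic acid could replace the aromatic ring at this position.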